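Compound 2 at a Limit, Compound 4 Still to Come

The source may hold more compounds than are shown below. What is called first, only, known or untested is meant among the compounds shown, and "the series" means these compounds.

Compound 1 `COc1cc(OC)c(OC)cc1/C=C/C(=O)c1cc(OC(C)=O)ccc1OC(C)=O` — 57900 nM
Compound 2 `COc1cc(OC)c(OC)cc1/C=C/C(=O)c1cc(Cl)ccc1O` — > 150000 nM
Compound 3 `COc1cc(OC)c(-c2cc(=O)c3ccc(O)cc3o2)cc1OC` — > 150000 nM

In a functional assay on HeLa cells (Homo sapiens) for inhibition, read by MTT assay, with a stated time of 72 h (on this read-out higher numbers stand for weaker inhibition and lower numbers for stronger inhibition), compound 1 gives 57900 nM. Compound 2 gives > 150000 nM, which is a limit of the assay and not a measured number. Compound 3 likewise gives > 150000 nM, again a limit. Compound 2 therefore stands at the limit of > 150000 nM in this assay, at which 2 of the 3 values shown sit, with no number of its own and nothing to separate it from compound 3. Compound 4 `COc1cc(OC)c(OC)cc1/C=C/C(=O)c1ccc(Br)cc1` has not yet been tested in this assay; it carries 4-bromophenyl in place of 5-chloro-2-hydroxyphenyl on a carbonyl carbon. For the measured compounds named here, no measured step covers this change, so the expectation rests on the limit alone: compound 4 is expected to show stronger inhibition than the limit, beyond the usual scatter, by an at least 3.7-fold lower number from compound 2 to compound 4 (0.57 log units; beyond the scatter). Compound 4 is accordingly estimated at 40000 nM, between 8000 nM and 150000 nM, with a real chance that only a limit is returned.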

Compound 4, half-maximal inhibitory concentration: 31700 nM
Beside the measured number, compound 4's estimate is 1.3-fold (0.10 log units) above it; measured number inside the range.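

On the carbonyl carbon, 4-bromophenyl in place of 5-chloro-2-hydroxyphenyl gives, in this assay, an at least 4.7-fold lower number from compound 2 to compound 4 (0.67 log units; beyond the scatter). This shows that the aryl group at this place can move the read-out off the limit, and that a group with 0 hydrogen-bond donors is enough for a measured number here. The step has only a lower bound, since the value for compound 2 is a limit and not a number: the limit of > 150000 nM in this assay, at which 2 of the 4 values shown sit.

For the compounds shown here, the single step does not separate the loss of the hydroxy group from the exchange of chlorine for bromine. As far as these compounds go, how an amine or a carboxylic acid on this ring would read remains open.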